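A few compounds are considered here, and "the series" means these few. Any claim that something is new, unique, unknown or untested is made for them only; others in the source may bear on it.

Measured in a toxicity assay on L02 cells (Homo sapiens) for cytotoxicity, read by MTT assay, with a stated time of 24 h; on this read-out higher numbers stand for lower toxicity in this test and lower numbers for higher toxicity in this test:
- compound 1 `CCCCS(=O)(=O)Oc1ccc(/C=C/C(=O)Nc2ccc(C)cc2)cc1OC`: 26800 nM
- compound 2 `COC(=O)/C=C/c1ccc(OS(=O)(=O)c2ccc(Cl)cc2)c(OC)c1`: 99500 nM
- compound 3 `COc1cc(/C=C/C(=O)Nc2cccc(C)c2)ccc1OS(=O)(=O)c1ccc(Cl)cc1`: 73500 nM

Compound 1 gives the lowest number of the three, and its gaps to both others lie beyond the scatter. Compound 4 `CCCCOC(=O)/C=C/c1ccc(OS(=O)(=O)CCCC)c(OC)c1` is not yet measured. It differs from compound 1 by butoxy in place of (4-methylphenyl)amino on a carbonyl carbon. The nearest measured evidence is a 1.4-fold lower number from compound 2 to compound 3 (0.13 log units; within the scatter), a swap between methoxy and (3-methylphenyl)amino at the same carbonyl carbon, and it stays within the scatter. It was measured on a different background from compound 1, so it is only a loose guide. Only a small rise is therefore expected, an estimated 1.3-fold higher number from compound 1 to compound 4 (0.12 log units; within the scatter). The estimate for compound 4 is 35000 nM, with an expected range of 15000 nM to 85000 nM.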

Compound 4, half-maximal cytotoxic concentration: 115000 nM
Compound 4: middle estimate off by 3.3-fold (0.52 log units), on the low side; measured number above the stated range.
By their numbers in this assay, from the lowest: compound 1; then compounds 3, 2 and 4 (each within the scatter of the next).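

In this assay, this carbonyl carbon carried a change beyond the scatter (a 4.3-fold higher number from compound 1 to compound 4 (0.63 log units; beyond the scatter)) when butoxy replaced (4-methylphenyl)amino. The earlier swap at this carbon, between methoxy and (3-methylphenyl)amino, stayed within the scatter (a 1.4-fold lower number from compound 2 to compound 3 (0.13 log units; within the scatter)), though it involved other groups on a different background. No measurement at hand accounts for this contrast. The compounds shown leave open whether the step follows the loss of the aromatic ring or of the amide hydrogen. They also leave open where a benzylamino group or a carboxylic acid at this carbon would fall.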